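This account rests on a few compounds, and the source may have more. Where it says the series, first, only, none or still open, it means among the compounds named here.

Measured so far:
compound 1, `COc1ccc(O)c(C(=O)Nc2ccc(C#N)cc2)c1`: > 10000 nM
compound 2, `N#Cc1ccc(NC(=O)c2ccc(Br)cc2O)c(Cl)c1`: 730 nM

Both compounds were tested in a functional assay on HL-60 cells (Homo sapiens) for cytotoxicity, read by luminescence and CellTiter-Glo, with a stated time of 3 days; on this read-out higher numbers stand for weaker inhibition and lower numbers for stronger inhibition. For compound 1 the result is not a number but a limit of the assay, (the limit of > 10000 nM in this assay, at which 1 of the 2 values shown sits), so the value of compound 1 is known only as a range. Compound 2 gives a measured number, 730 nM. For the measured compounds named here, no step between these two compounds has been worked out, so the two values stand side by side without a computed comparison.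

Compound 3, `N#Cc1ccc(NC(=O)c2cc(-c3ccccc3)ccc2O)cc1`, has not yet been measured in this assay. It differs from compound 1 in one place: phenyl in place of methoxy on an aromatic carbon. Because compound 1 sits at the limit (the limit of > 10000 nM in this assay, at which 1 of the 2 values shown sits), any numerical result for compound 3 would already mean a move toward stronger inhibition. The step from the starting point is expected to be an at least 3.3-fold lower number from compound 1 to compound 3 (0.52 log units; beyond the scatter), beyond the scatter. Compound 3 is estimated at 3000 nM, likely between 600 nM and 15000 nM.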

Compound 3, half-maximal inhibitory concentration: 1350 nM
For compound 3 the middle estimate is 2.2-fold (0.35 log units) above the measured one, within the range that was stated.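

In this assay, the position para to the hydroxy group now gives a measurable result: with phenyl in place of methoxy there, the change is an at least 7.4-fold lower number from compound 1 to compound 3 (0.86 log units; beyond the scatter). So on this core, a six-membered aromatic ring of carbon only at this position is compatible with a numerical result, which the methoxy compound did not give. From the compounds shown here alone, the true size of the step stays unknown because the result for compound 1 is a limit of the assay rather than a number: the limit of > 10000 nM in this assay, at which 1 of the 3 values shown sits.

With only methoxy and phenyl compared at this position, the data cannot separate the effect of an aromatic ring from that of a larger group. Going by these compounds, a saturated ring such as cyclohexyl or a ring carrying an amine would help test this, and how far the ring itself matters remains open.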